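Methoxycarbonyl in place of methylsulfonyl: outlook for compound 3

The source may hold more compounds than are shown below. What is called first, only, known or untested is meant among the compounds shown, and "the series" means these compounds.

Measured so far:
compound 1, `CC(C)(C)c1nc2c(C(=O)NCC3CCN(CC(O)CN4CCN(S(C)(=O)=O)CC4)CC3)cccc2[nH]1`: 3.16 nM
compound 2, `CC(C)c1nc2c(C(=O)NCC3CCN(CCN4CCN(S(C)(=O)=O)CC4)CC3)cccc2[nH]1`: 0.794 nM

In a functional assay for agonist activity at 5-hydroxytryptamine receptor 4 (Homo sapiens), read by cAMP accumulation (on this read-out lower numbers stand for an effect already at smaller amounts and higher numbers for an effect only at larger amounts of compound), compound 2 gives 0.794 nM, the lowest of the two numbers. Compound 1 gives 3.16 nM, a higher number that lies beyond the scatter. Among the compounds with values here, the two compounds differ in more than one place, so their values show only that compound 2 is the lower of the pair.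

Compound 3, `COC(=O)N1CCN(CCN2CCC(CNC(=O)c3cccc4[nH]c(C(C)C)nc34)CC2)CC1`, is not yet measured in this assay. It differs from compound 2 in one place: methoxycarbonyl in place of methylsulfonyl on an amine nitrogen in a ring. Within the data shown here, no measured pair shows this exchange. Both groups have no net charge and carry the same count of hydrogen-bond acceptors and donors, as counted above. The step expected is small, at most a modest move to higher numbers, and may stay within the scatter: a 1.6-fold higher number from compound 2 to compound 3 (0.21 log units; within the scatter). Compound 3 is estimated at 1.3 nM in this assay, with a range from 0.4 nM to 5 nM.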

Compound 3, half-maximal effective concentration: 1.59 nM
For compound 3 the middle estimate is 1.2-fold (0.09 log units) below the measured one, and the stated range covers the measured number.
By their numbers in this assay, from the lowest: compounds 2, 3 and 1 (each within the scatter of the next, the first and the last beyond it).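

In this assay, within the data shown here, methoxycarbonyl in place of methylsulfonyl on the amine nitrogen in the ring gives a 2.0-fold higher number from compound 2 to compound 3 (0.30 log units; within the scatter), the first step that can be read at a single place. Compounds 1 and 2 differ in more than one place and say nothing about this position, whereas this pair shows that the position takes either group without a difference that can be told from the scatter. No supporting measurement on either group bears on this result.

Open, from the compounds shown here alone, is whether an acetyl group, a plain methyl, a longer carbamate such as tert-butoxycarbonyl or an unsubstituted ring nitrogen would stay in the same range in this assay. Also open, going by these compounds, is whether the same exchange would give a similar step with the side chain and tert-butyl group of compound 1.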